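Furan-substituted naphthalene series: cytotoxicity notes on compound 4

The source may report more compounds than this note shows. Statements on the series, on what has been measured and on what is new or still open speak of the compounds shown alone.

Measured so far:
- compound 1, `CCOc1c(-c2occ(C)c2C(=O)O)ccc2c(CC)cccc12` — > 10 ug/mL
- compound 2, `CCCOC(=O)c1c(C)coc1-c1ccc2c(CC)cccc2c1OC` — > 10 ug/mL
- compound 3, `CCOc1c(-c2occ(C)c2C(=O)OC)ccc2c(CC)cccc12` — 1.9 ug/mL

Compound 1 is a free acid; in a functional assay on DU-145 cells (Homo sapiens) for cytotoxicity, read by MTT assay, with a stated time of 72 h (a higher number here means that more compound is needed for the effect, a lower number that less compound is needed), it reaches only the limit > 10 ug/mL. Compound 2, the propyl ester with a methoxy group on the shared core, likewise sits at the limit > 10 ug/mL. Compound 3, the methyl ester, gives 1.9 ug/mL in this assay. For the measured compounds named here, the one measured step, an at least 5.2-fold lower number from compound 1 to compound 3 (0.72 log units; beyond the scatter), is the only change in the set that moves the number beyond the scatter; compound 2 stands with compound 1 at the limit (the limit of > 10 ug/mL in this assay, at which 2 of the 3 values shown sit), and nothing beyond that is known of it.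

Compound 4, `CCc1cccc2c(OC)c(-c3occ(C)c3CBr)ccc12`, carries the change (bromomethyl in place of propoxycarbonyl on an aromatic carbon). Going by the values given here, no measured step covers an exchange of an ester for bromomethyl; the step from compound 1 to compound 3 speaks only to the ester oxygen. Within the set, the two ester compounds diverge, compound 3 giving a number and compound 2 a limit, so the ester is not by itself decisive. For compound 4 a number below the limit is expected, estimated at 5 ug/mL (range 1.5 ug/mL to 20 ug/mL), which would mean an expected step of an at least 2.0-fold lower number from compound 2 to compound 4 (0.30 log units; that floor lies within the scatter).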

Compound 4, concentration for half-maximal effect: > 10 ug/mL
Compound 4 ended at the assay's limit (the forecaster's own chance of this, stated with the estimate: 35%); at least 2.0-fold (0.30 log units) between middle value and limit.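

Compound 2 and compound 4 both stand at a limit in this assay, so no step can be read between them: the limit of > 10 ug/mL in this assay, at which 3 of the 4 values shown sit. The compounds shown leave open whether bromomethyl in place of propoxycarbonyl changes the outcome in this assay at all.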